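Swapping Hydroxy for Anilino on a Carbonyl Carbon

The source may hold more compounds than are shown below. What is called first, only, known or untested is meant among the compounds shown, and "the series" means these compounds.

Compound 1 `O=C(O)CCCCC(CCSC(=O)c1ccccc1)SC(=O)c1ccccc1`: "not active" (no number reported)
Compound 2 `CC(=O)SCCC(CCCCC(=O)Nc1ccccc1Cl)SC(C)=O`: 2.48%

In a functional assay on HO8910 cells (Homo sapiens) for inhibition, read by MTT assay, with a stated time of 24 h, tested at 0.1 ug/mL (a higher number here means more inhibition of growth at the concentration tested, a lower number less inhibition of growth), compound 1 is reported as "not active" (no number reported) and has no number, so it cannot be placed exactly on the scale. It can only be read as showing no useful inhibition of growth at the concentration tested.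

The next compound to be tested is compound 3 `O=C(CCCCC(CCSC(=O)c1ccccc1)SC(=O)c1ccccc1)Nc1ccccc1`, which keeps the core of compound 1 and changes one place. Carboxy becomes phenylcarbamoyl (anilino in place of hydroxy on a carbonyl carbon).

Among the compounds with values here, no measured pair shows this exact change, so any forecast is loose. Of the measured compounds, only compound 2 has an amide at that carbonyl, and compound 2 gives 2.48% in this assay. A small upward step is therefore expected, probably not beyond the usual scatter.

For compound 3 the estimated inhibition is 5%, with an expected range from 0% to 20% in this estimate.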

Compound 3, percent growth inhibition at one concentration: 3.12%
Estimate against measurement, compound 3: 1.9 percentage points above, within the range that was stated.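

In this assay compound 1 stands as "not active" (no number reported) and compound 3 gives 3.12% so no step can be read between these two compounds. Going by these compounds, how far phenylcarbamoyl in place of carboxy shifts growth inhibition on the core of compound 1 stays open. No supporting measurement bears on this result.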